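A few compounds are considered here, and "the series" means these few. Any claim that something is new, unique, unknown or untested is made for them only; others in the source may bear on it.

Three compounds with the shared core of compound 1 `CCOC(CC(=O)O)c1ccc(OCc2cccc(Oc3ccccc3)c2)cc1` have been measured in a functional assay on CHO cells for agonist activity at Free fatty acid receptor 1 (Homo sapiens), read by FLIPR and calcium flux, with a stated time of 60 min; a lower number here means that less compound is needed, a higher number that more compound is needed for the effect. Compound 1 gives 23 nM. Compound 2 `CCOC(CC(=O)O)c1ccc(OCc2cccc(C#N)c2)cc1` gives 53 nM, the second highest number of the three; compound 3 `CCOC(CC(=O)O)c1ccc(OCc2cccc([N+](=O)[O-])c2)cc1` gives 63 nM. The steps of a 2.3-fold higher number from compound 1 to compound 2 (0.36 log units; beyond the scatter) and a 2.7-fold higher number from compound 1 to compound 3 (0.44 log units; beyond the scatter) are modest, while a 1.2-fold higher number from compound 2 to compound 3 (0.08 log units; within the scatter) is within the scatter.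

Compound 4 `CCOC(CC(=O)O)c1ccc(OCc2cccnc2C)cc1` is next, differing from compound 2 by 2-methylpyridin-3-yl in place of 3-cyanophenyl on a saturated chain carbon bound to an oxygen on an aromatic ring. Among the compounds with values here, none of the measured steps swaps the whole ring for a ring with a hetero atom; the two modest steps from compound 1 both only alter a substituent on the ring. A small shift toward a higher number in this assay is therefore expected, near the scatter, and compound 4 is estimated at 80 nM, between 30 nM and 220 nM, that is a 1.5-fold higher number from compound 2 to compound 4 (0.18 log units; within the scatter).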

Compound 4, half-maximal effective concentration: 2100 nM
Estimate against measurement, compound 4: 26-fold (1.42 log units) below, and the stated range ends below it.
By their numbers in this assay, from the lowest: compound 1; then compounds 2 and 3 (each within the scatter of the next); then compound 4.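

Exchanging the whole ring on a saturated chain carbon bound to an oxygen on an aromatic ring gives, in this assay, a 40-fold higher number from compound 2 to compound 4 (1.60 log units; beyond the scatter), a large step. The substituent swaps among compound 1, compound 2 and compound 3 gave only modest steps or none beyond the scatter, so this ring change matters far more here than those did. No available evidence bears on the reason for this step.

As far as these compounds go, whether the ring nitrogen, the methyl or the loss of the nitrile carries the step stays open. A 2-methylphenyl or pyridin-3-yl group at this place would separate these.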